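The compounds below may be only part of what the source reports. "The series", "measured", "known", "first", "only" and "open" are said of these compounds alone.

Measured so far in a functional assay on EOL1 cells (Homo sapiens) for inhibition, read by fluorescence, with a stated time of 72 h; on this read-out lower numbers stand for stronger inhibition of growth and higher numbers for weaker inhibition of growth:
compound 1 `CC(C)CCn1cnc2c(Nc3ccc(Cl)cc3)nc(N[C@H]3CC[C@H](N)CC3)nc21` gives 90 nM
compound 2 `CCCCCCn1cnc2c(Nc3ccc(Cl)cc3)nc(N[C@H]3CC[C@H](N)CC3)nc21` gives 440 nM
compound 3 `COc1cc(Nc2nc(N[C@H]3CC[C@H](N)CC3)nc3c2ncn3CCC(C)C)cc(OC)c1` gives 140 nM

Compound 4 `CCCCCCn1cnc2c(Nc3cc(OC)cc(OC)c3)nc(N[C@H]3CC[C@H](N)CC3)nc21` is not yet measured in this assay.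

Two changes are seen among the measured compounds. From compound 1 to compound 2 the change is butyl in place of isopropyl on a saturated chain carbon, two bonds along the chain from an aromatic nitrogen and it made a step of a 4.9-fold higher number from compound 1 to compound 2 (0.69 log units; beyond the scatter) in this assay. From compound 1 to compound 3 the change is 3,5-dimethoxyphenyl in place of 4-chlorophenyl on a nitrogen on an aromatic ring and it made a step of a 1.6-fold higher number from compound 1 to compound 3 (0.19 log units; within the scatter), so compound 1 and compound 3 are not separated in this assay.

Compound 4 is reached from compound 3 by butyl in place of isopropyl on a saturated chain carbon, two bonds along the chain from an aromatic nitrogen. This is the same change as that from compound 1 to compound 2, at the same place on the chain, and the only difference between the two cores is 3,5-dimethoxyphenyl in place of 4-chlorophenyl on a nitrogen on an aromatic ring. Compound 1 and compound 3 stand close together with a 1.6-fold higher number from compound 1 to compound 3 (0.19 log units; within the scatter). For the measured compounds named here, the one measured step for this same change is a 4.9-fold higher number from compound 1 to compound 2 (0.69 log units; beyond the scatter). A step of similar size is expected on going from compound 3 to compound 4, with the rest of the structure unchanged; this rests on a single measured pair, so the width of the expectation is kept broad.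

Compound 4 is expected to show a step of a 4.9-fold higher number from compound 3 to compound 4 (0.69 log units; beyond the scatter) in this assay. The estimate for compound 4 is 690 nM, between 250 nM and 1900 nM.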

Compound 4, concentration for 50% growth inhibition: 380 nM
Compound 4: the middle estimate sits 1.8-fold (0.26 log units) above what was measured, and the stated range covers the measured number.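

In this assay the change of butyl in place of isopropyl on the chain gives a 2.7-fold higher number from compound 3 to compound 4 (0.43 log units; beyond the scatter), so the step beyond the scatter seen on the core of compound 1 also appears on the core bearing 3,5-dimethoxyphenyl, and the two steps cannot be told apart: the same change on two cores in this assay, a 4.9-fold higher number (0.69 log units; beyond the scatter) from compound 1 to compound 2 and a 2.7-fold higher number (0.43 log units; beyond the scatter) from compound 3 to compound 4, 1.8-fold (0.26 log units) apart, within the scatter of two such steps. The exchange of 4-chlorophenyl for 3,5-dimethoxyphenyl on the hexyl compounds gives a 1.2-fold lower number from compound 2 to compound 4 (0.06 log units; within the scatter), which separates neither pair, and this change likewise reads alike on the two chains: the same change on two cores in this assay, a 1.6-fold higher number (0.19 log units; within the scatter) from compound 1 to compound 3 and a 1.2-fold lower number (0.06 log units; within the scatter) from compound 2 to compound 4, 1.8-fold (0.26 log units) apart, within the scatter of two such steps. These notes show that both changes carry across this one pair of cores, but with a single pair for each comparison they do not fix the size of either step, do not extend to other groups on the aromatic amine, and do not explain the loss of growth inhibition with the hexyl chain.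

The compounds shown span only the isopentyl and hexyl chains, leaving open how the number behaves with a shorter chain such as ethyl, or with a chain ending in a hydroxyl or an amine. Also open, as far as these compounds go, is whether the step holds with a pyridine in place of the phenyl ring, or with an amide in place of the free primary amine.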